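Replacing the sulfur link by oxygen in a benzimidazole series

The source may hold more compounds than are shown below. What is called first, only, known or untested is meant among the compounds shown, and "the series" means these compounds.

Of the compounds shown here, three sharing one core have been measured so far. Compound 1 `Clc1ccc2[nH]c(SCc3ccccc3Oc3ccccc3)nc2c1` carries a phenoxy group; in an assay on isolated protein for inhibition of Indoleamine 2,3-dioxygenase 1 (Homo sapiens), with a stated time of 60 min, tested at 10 uM (a higher number here means more inhibition at the concentration tested (going by the name of the read-out), a lower number less inhibition), compound 1 gives 30%. Compound 2 `Clc1ccc2[nH]c(SCc3ccccc3CCCc3ccccc3)nc2c1` carries a 3-phenylpropyl group in its place, and compound 2 gives 19%. Compound 3 `Clc1ccc2[nH]c(SCc3ccccc3SCc3ccccc3)nc2c1` carries a benzylsulfanyl group, and compound 3 gives 19%. Compound 3 thus stands level with compound 2, the two together being the lowest of the three, while the step of a number 11 percentage points lower from compound 1 to compound 3 (beyond the scatter) shows compound 1 standing higher, beyond the scatter.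

Compound 4 `Clc1ccc2[nH]c(SCc3ccccc3OCc3ccccc3)nc2c1` differs from compound 3 in one place: benzyloxy in place of benzylsulfanyl on an aromatic carbon. Going by these compounds, the steps bearing on this are a number 11 percentage points lower from compound 1 to compound 3 (beyond the scatter) and no change at the digits printed from compound 2 to compound 3 (within the scatter), but none of them swaps sulfur for oxygen within the same chain, so the direct effect is unknown. A small rise or no change beyond the scatter is expected, giving the estimated step of a number 4 percentage points higher from compound 3 to compound 4 (within the scatter). Compound 4 is therefore expected to give about 23%, within a range from 10% to 38%.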

Compound 4, a percentage reported as inhibition, at one concentration (the size of the read-out at that concentration, not a potency): 3%
Compound 4: the middle estimate sits 20 percentage points above what was measured; measured number below the stated range.
By their numbers in this assay, from the lowest: compound 4; then compounds 2 and 3 (each within the scatter of the next); then compound 1.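

At this place on the aromatic ring, the linking atom alone matters: benzyloxy and benzylsulfanyl match in heavy atoms, hydrogen-bond donors and acceptors, yet in this assay the swap gives a number 16 percentage points lower from compound 3 to compound 4 (beyond the scatter) and so separates two groups that the counts cannot tell apart. Having oxygen on the ring does not by itself keep the number up, as the steps of a number 16 percentage points lower from compound 2 to compound 4 (beyond the scatter) and a number 27 percentage points lower from compound 1 to compound 4 (beyond the scatter) show, the second of them changing only phenyl to benzyl on that oxygen. Nothing measured here explains why the swap of sulfur for oxygen, or the added benzyl carbon, lowers the number.

Going by these compounds, whether a nitrogen link, as in a benzylamino group, would behave like the sulfur or the oxygen remains open. So does the effect of a longer chain on the oxygen, such as 3-phenylpropoxy, at this place.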